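Moving the nitrile off and a hydroxyl on: compound 3

The compounds below may be only part of what the source reports. "The series", "measured", "known", "first", "only" and "open" are said of these compounds alone.

The series rests on a shared core, carried in compound 1 `CC1(C)[C@H]2CC[C@]1(C)N(Cc1cn(-c3ccccc3C#N)nn1)C(=O)C2` and compound 2 `CC1(C)[C@H]2CC[C@]1(C)N(Cc1cn(-c3cccc(C#N)c3)nn1)C(=O)C2`, where the two differ only in the aryl group on the triazole nitrogen. In a functional assay on PANC-1 cells (Homo sapiens) for inhibition, read by MTT assay, with a stated time of 24 h (a higher number here means a weaker inhibitor, a lower number a stronger inhibitor), compound 1 gives 240 nM, and compound 2 gives 260 nM. Compound 1 stands with the lowest of the two numbers, yet its nearest neighbour is close: a 1.1-fold higher number from compound 1 to compound 2 (0.03 log units; within the scatter). Compound 3 `CC1(C)[C@H]2CC[C@]1(C)N(Cc1cn(-c3ccc(O)cc3)nn1)C(=O)C2` is the next member; the change from compound 1 is 4-hydroxyphenyl in place of 2-cyanophenyl on an aromatic nitrogen. Among the measured compounds shown here, the only measured step that touches the same position is the one from compound 1 to compound 2, which swaps the cyanophenyl pattern and stays within the scatter. That step says little about exchanging the nitrile for a hydroxyl, so the expectation for compound 3 rests on a single nearby observation and carries a wide range. In this assay compound 3 is expected to give 320 nM, between 120 nM and 900 nM. The estimated change from compound 1 to compound 3 is a 1.3-fold higher number from compound 1 to compound 3 (0.12 log units; within the scatter), a small weakening that may not exceed the scatter.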

Compound 3, half-maximal inhibitory concentration: 100 nM
The estimate for compound 3 lay 3.2-fold (0.51 log units) above the measured number; the whole stated range lies above it.
By their numbers in this assay, from the lowest: compound 3; then compounds 1 and 2 (each within the scatter of the next).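

In this assay the group on this aromatic nitrogen proved able to move the number, which the shift of the nitrile from 2-cyanophenyl to 3-cyanophenyl had not shown: the exchange for 4-hydroxyphenyl gives a 2.4-fold lower number from compound 1 to compound 3 (0.38 log units; beyond the scatter) and also a 2.6-fold lower number from compound 2 to compound 3 (0.41 log units; beyond the scatter) in a modest change from either cyanophenyl compound. Compound 3 is therefore the strongest of the three inhibitors here, and the direction of the change is the same from both starting points, with a hydroxyl-bearing ring in place of a nitrile-bearing one. Nothing available accounts for this gain in inhibition.

The step changes several things at once, as the nitrile leaves, the hydroxyl enters and the substituent takes a different place on the phenyl ring, so the compounds shown cannot say which of these carries the difference. An unsubstituted phenyl, a 4-cyanophenyl or a 2-hydroxyphenyl on the same nitrogen would begin to separate them, and a 4-methoxyphenyl or a 4-aminophenyl would test whether the lower number depends on the hydroxyl itself.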